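Trading a Methyl for Hydrogen on the Ring Nitrogen

The source may hold more compounds than are shown below. What is called first, only, known or untested is meant among the compounds shown, and "the series" means these compounds.

Of the compounds shown here, three built on closely related cores have been tested in a functional assay on PA-1 cells (Homo sapiens) for cytotoxicity, read by MTT assay, with stated times of 6 h and 48 h; on this read-out higher numbers stand for weaker inhibition and lower numbers for stronger inhibition. Compound 1 `COc1ccc(C(=O)/C=C/c2cc(Br)c(Br)n2C)c(OC)c1` gives 520 nM. Compound 2 `COc1ccc(OC)c(C(=O)/C=C/c2cc(Br)c(Br)n2C)c1` has the same atoms as compound 1 joined differently; the difference between the two cores is not broken down here. In this assay compound 2 gives 800 nM, which lies within the scatter of compound 1. Compound 3 `COc1ccc(C(=O)/C=C/c2cc(Br)c(Br)[nH]2)c(OC)c1` is compound 1 with hydrogen in place of methyl on an aromatic nitrogen, and in this assay compound 3 gives 320 nM. The step of a 1.6-fold lower number from compound 1 to compound 3 (0.21 log units; within the scatter) stays within the scatter, so the two numbers cannot be told apart with confidence. Compound 2 and compound 3 are further apart, beyond the scatter, with compound 2 giving the higher number.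

Compound 4 `COc1ccc(OC)c(C(=O)/C=C/c2cc(Br)c(Br)[nH]2)c1` has not yet been measured. Among the measured compounds shown here, it is related to compound 2 by hydrogen in place of methyl on an aromatic nitrogen, the same change, at the same place, as the one that turns compound 1 into compound 3. For the measured compounds named here, that single earlier step is the only guide available. The step from compound 2 to compound 4 is expected to be of a similar size, a 1.6-fold lower number from compound 2 to compound 4 (0.20 log units; within the scatter), because the earlier step of a 1.6-fold lower number from compound 1 to compound 3 (0.21 log units; within the scatter) was small. On that basis compound 4 is estimated to give 500 nM in this assay, with a likely range from 250 nM to 1000 nM.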

Compound 4, half-maximal inhibitory concentration: 420 nM
Compound 4: middle estimate off by 1.2-fold (0.08 log units), on the high side; measured number inside the range.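

In this assay, putting hydrogen in place of methyl on the aromatic nitrogen of the core of compound 2 gives a 1.9-fold lower number from compound 2 to compound 4 (0.28 log units; within the scatter), so this pair of numbers cannot be told apart with confidence. The same change on the core of compound 1 gave a step of much the same size, and the two steps cannot be told apart either: the same change on two cores in this assay, a 1.6-fold lower number (0.21 log units; within the scatter) from compound 1 to compound 3 and a 1.9-fold lower number (0.28 log units; within the scatter) from compound 2 to compound 4, 1.2-fold (0.07 log units) apart, within the scatter of two such steps. This shows that, across these two cores, the change behaves consistently and leaves the cytotoxicity read-out about where it was, but it does not show that removing the methyl truly strengthens inhibition, since neither step stands clear of the scatter, and two cores are too few to establish a rule for the whole series.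

Among the compounds shown, only methyl and hydrogen appear on this aromatic nitrogen, so it remains open what a longer chain such as ethyl, or a chain ending in an amine or a carboxylic acid, would do at the same place. As far as these compounds go, it also remains open whether the small step seen here would hold on a different core, or in a different assay.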